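Sulfonamide in place of hydroxy on the cyclohexyl ring

A few compounds are considered here, and "the series" means these few. Any claim that something is new, unique, unknown or untested is made for them only; others in the source may bear on it.

Within the data shown here, compound 1 `O=c1cc(N2CCN(CC3CCC(O)CC3)CC2)sc2c([N+](=O)[O-])cc(C(F)(F)F)cc12` holds the highest of the two numbers measured so far: in an ADME assay on cells (Hepatocyte, Mus musculus) for metabolic stability, with a stated time of 30 min (on this read-out lower numbers stand for a less stable compound and higher numbers for a more stable compound), compound 1 gives 51.2%. Its nearest neighbour, compound 2 `O=C(OC1CCC(CN2CCN(c3cc(=O)c4cc(C(F)(F)F)cc([N+](=O)[O-])c4s3)CC2)CC1)c1ccc(F)cc1`, gives in this assay only 1.5%; the step of a number 49.7 percentage points lower from compound 1 to compound 2 (beyond the scatter) goes with (4-fluorophenyl)carbonyl in place of hydrogen on the oxygen. Compound 3 `O=c1cc(N2CCN(CC3CCC(NS(=O)(=O)c4ccccc4)CC3)CC2)sc2c([N+](=O)[O-])cc(C(F)(F)F)cc12` differs from compound 1 by (phenylsulfonyl)amino in place of hydroxy on a saturated ring carbon. As this again adds a six-membered aromatic ring at the same saturated ring carbon, a drop in this assay beyond the scatter is expected, though a smaller one is estimated. Compound 3 is estimated at 20% (range 5% to 45%), meaning a number 31.2 percentage points lower from compound 1 to compound 3 (beyond the scatter).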

Compound 3, percent of the compound remaining: 95.3%
The estimate for compound 3 lay 75.3 percentage points below the measured number; the whole stated range lies below it.
By their numbers in this assay, from the lowest: compound 2; then compound 1; then compound 3.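

A six-membered aromatic ring carried at this saturated ring carbon does not in itself go with a loss in this assay, since the change to (phenylsulfonyl)amino gives a number 44.1 percentage points higher from compound 1 to compound 3 (beyond the scatter) in the direction opposite to that seen with ((4-fluorophenyl)carbonyl)oxy. The outcome at this position therefore depends on more than the presence of the aromatic ring, as the comparison of the two large groups gives a number 93.8 percentage points higher from compound 2 to compound 3 (beyond the scatter) and shows. The data offer no explanation for this reversal.

That comparison changes both the link to the ring and the fluorine, so their shares stay unseparated. As far as these compounds go, whether the phenyl ring is needed at all remains open, and (methylsulfonyl)amino or a plain amino group at this carbon would address that.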